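Replacing One Six-Membered Ring by Another: Permeability Outlook

The compounds below may be only part of what the source reports. "The series", "measured", "known", "first", "only" and "open" are said of these compounds alone.

Measured so far:
- compound 1, `COc1ccccc1C(=O)NC(=O)Nc1ccc(-c2ccccn2)c(C(F)(F)F)c1`: 7.4 10^-6 cm/s
- compound 2, `COc1ccncc1C(=O)NC(=O)Nc1ccc(-c2ccccc2)c(C(F)(F)F)c1`: 2.3 10^-6 cm/s

In an ADME assay on LLC-PK1 cells (Sus scrofa) for permeability (a higher number here means that the compound crosses the layer faster, a lower number that the compound crosses the layer more slowly), compound 1 gives 7.4 10^-6 cm/s, the higher of the two numbers measured; compound 2 gives 2.3 10^-6 cm/s, a gap beyond the usual scatter, although the two compounds differ in more than one place, so nothing can be drawn from that gap for a single change. The new compound 3, `COc1ccccc1C(=O)NC(=O)Nc1ccc(N2CCCCC2)c(C(F)(F)F)c1`, is built from compound 1 by one change only: piperidin-1-yl in place of pyridin-2-yl on an aromatic carbon. Within the data shown here, no measured pair shows this particular change, so the step can only be guessed. Since compound 1 gives 7.4 10^-6 cm/s in this assay, compound 3 is expected to stay close to it, with a step of a 1.1-fold lower number from compound 1 to compound 3 (0.02 log units; within the scatter) that may well lie within the scatter. The estimate for compound 3 is 7 10^-6 cm/s, in a range from 3 10^-6 cm/s to 15 10^-6 cm/s.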

Compound 3, apparent permeability: < 1 10^-6 cm/s
Compound 3 gave a limit, no number (the forecaster's own chance of this, stated with the estimate: 5%); at least 7.0-fold (0.84 log units) between middle value and limit.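

In this assay, the group on the aromatic carbon ortho to the trifluoromethyl group clearly matters: piperidin-1-yl in place of pyridin-2-yl brings an at least 7.4-fold lower number from compound 1 to compound 3 (0.86 log units; beyond the scatter). The two groups have the same count of heavy atoms, the same count of hydrogen-bond donors and acceptors, and no net charge, and one visible difference is that one ring is aromatic and the other is not, so these counts alone do not predict the outcome of this change. The reading for compound 3 is a limit of the assay and not a number: the limit of < 1 10^-6 cm/s in this assay, at which 1 of the 3 values shown sits.

The compounds shown leave open how other groups at this position would read, such as cyclohexyl, morpholin-4-yl or a dimethylamino group. They also do not tell whether the non-aromatic ring itself or the way it is attached lies behind the step.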